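Swapping the terminal amine at the chain end

The compounds below may be only part of what the source reports. "The series", "measured", "known", "first", "only" and "open" are said of these compounds alone.

Measured compounds:
compound 1 `COc1cc2c(Oc3ccc(NC(=O)c4nn(-c5ccccc5C)c(=O)cc4C)cc3F)ccnc2cc1OCCCN1CCN(C)CC1`: 3790 nM
compound 2 `COc1cc2c(Oc3ccc(NC(=O)c4nn(-c5ccccc5OC(F)(F)F)c(=O)cc4C)cc3F)ccnc2cc1OCCCN1CCCC1`: 180 nM
compound 3 `COc1cc2c(Oc3ccc(NC(=O)c4nn(-c5ccccc5OC(F)(F)F)c(=O)cc4C)cc3F)ccnc2cc1OCCCN1CCCCC1`: 190 nM

In a functional assay on HT-29 cells (Homo sapiens) for inhibition, read by MTT assay, with a stated time of 72 h (on this read-out lower numbers stand for stronger inhibition and higher numbers for weaker inhibition), compound 3 gives 190 nM, the second highest of the three numbers shown. Compound 2 gives 180 nM, within the scatter of compound 3, whereas compound 1 gives 3790 nM, a difference that lies beyond the scatter. Compound 4 `COc1cc2c(Oc3ccc(NC(=O)c4nn(-c5ccccc5OC(F)(F)F)c(=O)cc4C)cc3F)ccnc2cc1OCCCN1CCN(C)CC1` differs from compound 3 by 4-methylpiperazin-1-yl in place of piperidin-1-yl on a saturated chain carbon, three bonds along the chain from an oxygen on an aromatic ring. For the measured compounds named here, the only measured step that bears on this is a 1.1-fold higher number from compound 2 to compound 3 (0.02 log units; within the scatter), an exchange of one saturated amine ring for another at the same place, and it stayed within the scatter. Compound 1 carries the same 4-methylpiperazin-1-yl group but differs elsewhere, so its number cannot be set directly against compound 3. Compound 4 is therefore expected to show a 1.3-fold higher number from compound 3 to compound 4 (0.12 log units; within the scatter), nothing beyond the scatter, with an estimate of 250 nM and a range of 80 nM to 900 nM.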

Compound 4, half-maximal inhibitory concentration: 180 nM
Beside the measured number, compound 4's estimate is 1.4-fold (0.14 log units) above it, and the stated range covers the measured number.
By their numbers in this assay, from the lowest: compounds 2, 4 and 3 (each within the scatter of the next); then compound 1.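

Across this assay the 4-methylpiperazin-1-yl group stands level with both other saturated amine rings at this place, with a 1.1-fold lower number from compound 3 to compound 4 (0.02 log units; within the scatter) and no change at the digits printed from compound 2 to compound 4 (within the scatter) both printed as within the scatter. With that ring held constant, trifluoromethoxy in place of methyl on an aromatic carbon accounts for a 21-fold lower number from compound 1 to compound 4 (1.32 log units; beyond the scatter) in this pair, so the high number of compound 1 goes with that aromatic substituent and not with its amine ring. No measurement at hand explains either result.

As far as these compounds go, whether morpholin-4-yl or an open-chain dimethylamino group at the chain end would stay within the same scatter remains open. So does where methoxy or chloro in place of trifluoromethoxy would fall.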